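The compounds below may be only part of what the source reports. "The series", "measured", "known", "first", "only" and "open" are said of these compounds alone.

Of the compounds shown here, three have been measured so far: compound 1 `COc1cc(C2Oc3c(OC)cc(/C=C/C=O)cc3C2COC(=O)c2ccc(O)cc2)ccc1O`, compound 2 `COc1cc([C@H](O)[C@H](CO)Oc2c(OC)cc(-c3cc(=O)c4c(O)cc(O)cc4o3)cc2OC)ccc1O` and compound 3 `COc1cc([C@H]2Oc3c(OC)cc(/C=C/COC(=O)c4ccc(O)cc4)cc3[C@@H]2COC(=O)c2ccc(O)cc2)cc(OC)c1O`. In a functional assay, read by chemiluminescence (on this read-out higher numbers stand for weaker inhibition and lower numbers for stronger inhibition), compound 1 gives 19100 nM, compound 2 gives 13300 nM and compound 3 gives 25700 nM. Compound 3 carries the highest of the three numbers, yet its gap to compound 1 and its gap to compound 2 both fall within the usual scatter of repeated measurements, so the three figures cannot be placed in any reliable order; all three sit in the same weak range.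

The next compound, compound 4 `COc1cc([C@H]2Oc3c(OC)cc(/C=C/COC(=O)c4ccc(O)cc4)cc3[C@@H]2COC(=O)c2ccc(O)cc2)ccc1O`, differs from compound 3 in one place: hydrogen in place of methoxy on an aromatic carbon. Going by the values given here, no pair among the measured compounds isolates this change, so there is no measured step to lean on. What the data do show is that three compounds with quite different substitution patterns all land within the scatter of one another, which gives no sign that a small change of this kind would move the number far. The step from compound 3 to compound 4 is therefore expected to be small, in no definite direction, and not beyond the scatter, as a 1.2-fold lower number from compound 3 to compound 4 (0.07 log units; within the scatter). Compound 4 is accordingly estimated at 22000 nM, with a plausible range from 9000 nM to 55000 nM.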

Compound 4, half-maximal inhibitory concentration: 23700 nM
Beside the measured number, compound 4's estimate is 1.1-fold (0.03 log units) below it; the range from low to high includes it.
By their numbers in this assay, from the lowest: compounds 2, 1, 4 and 3 (each within the scatter of the next).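

In this assay, going by these compounds alone, the change from 4-hydroxy-3,5-dimethoxyphenyl to 4-hydroxy-3-methoxyphenyl gives a 1.1-fold lower number from compound 3 to compound 4 (0.04 log units; within the scatter) and is the first step that isolates a single place. Within the data shown here, at this position on the aromatic ring, ortho to a hydroxy group, hydrogen and methoxy therefore cannot be told apart on this read-out, whereas the earlier compounds, which differed in several places at once, could say nothing about this position alone. Nothing among the available data explains this result or bears on it directly.

On these data alone, what remains open is whether any other group at this position, such as an amine, a fluorine atom or a longer ethoxy chain, would shift the number beyond the scatter, since hydrogen and methoxy are the only two substituents compared here. The compounds shown also leave unresolved whether the hydroxy group, the remaining methoxy group or either of the two 4-hydroxybenzoate esters contributes to the weak inhibition, as no single-place step covers any of them.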